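The source may report more compounds than this note shows. Statements on the series, on what has been measured and on what is new or still open speak of the compounds shown alone.

Measured so far:
- compound 1 `O=C(NO)c1ccc(NCc2nc(-c3cccc(Cl)c3)nn2-c2ccccc2)cc1` gives 5760 nM
- compound 2 `Cc1cccc(-c2nc(CNc3ccc(C(=O)NO)cc3)n(-c3ccccc3)n2)c1` gives 8710 nM

These values come from a functional assay on MGC-803 cells (Homo sapiens) for antiproliferative activity, read by MTT assay, with a stated time of 72 h; on this read-out lower numbers stand for stronger inhibition and higher numbers for weaker inhibition. Compound 2, at 8710 nM, lies within the scatter of compound 1.

Compound 3 `O=C(NO)c1ccc(NCc2nc(-c3ccccc3Cl)nn2-c2ccccc2)cc1` differs from compound 2 by 2-chlorophenyl in place of 3-methylphenyl on an aromatic carbon. Going by the values given here, the only measured step that bears on it is a 1.5-fold higher number from compound 1 to compound 2 (0.18 log units; within the scatter), with methyl in place of chloro. Among the compounds with values here, no measured compound carries the 2-chlorophenyl group, so support is thin and no step beyond the scatter is expected in this assay. The expected change is a 1.2-fold lower number from compound 2 to compound 3 (0.09 log units; within the scatter). For compound 3 the estimated value is 7000 nM, with an expected range of 2500 nM to 20000 nM.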

Compound 3, half-maximal inhibitory concentration: > 20000 nM
Compound 3 ended at the assay's limit (the forecaster's own chance of this, stated with the estimate: 3%); middle value at least 2.8-fold (0.45 log units) from the limit.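

Compound 3 is a limit of the assay, not a number: the limit of > 20000 nM in this assay, at which 1 of the 3 values shown sits.

Even so, this position, on the aromatic carbon between two ring nitrogen atoms, proves sensitive: 2-chlorophenyl gives an at least 2.2-fold higher number from compound 2 to compound 3 (0.36 log units; beyond the scatter), and against 3-chlorophenyl it gives an at least 3.4-fold higher number from compound 1 to compound 3 (0.54 log units; beyond the scatter). Compound 1 and compound 2 showed no step beyond the scatter, so the change from 3-chlorophenyl to 2-chlorophenyl shows a dependence on the place of the chlorine that methyl in place of chloro did not.

As far as these compounds go, how far compound 3 lies past its limit stays open. So does the response of this position to 4-chlorophenyl, 2-methylphenyl or a phenyl bearing an amine.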